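Swapping vinyl for pent-1-en-1-yl on compound 2

The source may hold more compounds than are shown below. What is called first, only, known or untested is meant among the compounds shown, and "the series" means these compounds.

Measured in an ADME assay on L02 cells (Homo sapiens) for cytotoxicity, read by MTT assay, with a stated time of 72 h; a higher number here means a weaker inhibitor, a lower number a stronger inhibitor:
- Compound 1 `C=CC(=O)Nc1cccc(Oc2nc(Nc3ccn(C)n3)nc3c2CSCC3)c1`: > 50000 nM (a limit)
- Compound 2 `C=CC(=O)Nc1cccc(Oc2nc(Nc3cccc(C#N)c3)nc3c2CSCC3)c1`: > 50000 nM (a limit)

Compound 2 gives > 50000 nM, which is a limit of the assay and not a number. Compound 3 `CCC/C=C/C(=O)Nc1cccc(Oc2nc(Nc3cccc(C#N)c3)nc3c2CSCC3)c1` differs from it in one group: pent-1-en-1-yl in place of vinyl on a carbonyl carbon. In short, pent-1-en-1-yl takes the place of vinyl on a carbonyl carbon.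

For the measured compounds named here, the only measured step, a step that the two limits leave unreadable from compound 1 to compound 2, swaps a group on a nitrogen on an aromatic ring, not this one, and its size cannot be read. Going by the values given here, the one other guide is the limit of > 50000 nM in this assay, at which 2 of the 2 values shown sit. No step beyond the scatter can therefore be expected in this assay, in either direction, and another limit is the likeliest report. The expected change is a number no higher from compound 2 to compound 3 (the limit leaves the size open). For compound 3 the estimated value is 50000 nM, with an expected range from 25000 nM to 100000 nM.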

Compound 3, half-maximal inhibitory concentration: > 50000 nM
Compound 3 ended at the assay's limit; the forecaster's own chance of this, stated with the estimate: 80%; the middle value lies on the limit itself.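

In this assay compound 3 gives > 50000 nM, a limit of the assay and not a number. For the compounds shown here, compound 2 gives > 50000 nM, also a limit, so no step between compound 2 and compound 3 can be read. The compounds shown leave open whether pent-1-en-1-yl in place of vinyl on a carbonyl carbon changes the half-maximal inhibitory concentration at all.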